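Chloro for Methyl: A Repeated Swap Near Full Response

The source may report more compounds than this note shows. Statements on the series, on what has been measured and on what is new or still open speak of the compounds shown alone.

Four compounds that share one backbone are compared in a functional assay on NIH3T3 cells for agonist activity at Urotensin-2 receptor (Homo sapiens), with a stated time of 5 days; a higher number here means a larger maximal response, a lower number a smaller maximal response. Compound 1 `COc1ccc(/C=C/C(=O)NC(CCN(C)C)c2ccc(C)cc2)cc1` gives 79%. Among the measured compounds shown here, compound 2 `COc1ccc(/C=C/C(=O)NC(CCN(C)C)c2ccc(Cl)cc2)cc1` gives 99%, and the single change that turns compound 1 into compound 2 is chloro in place of methyl on an aromatic carbon; that change gave a number 20 percentage points higher from compound 1 to compound 2 (beyond the scatter). Compound 3 `Cc1ccc(C(CCN(C)C)NC(=O)/C=C/c2ccccc2)cc1` gives 97%. Its core differs from the core of compound 1 by hydrogen in place of methoxy on an aromatic carbon, and that change gave a number 18 percentage points higher from compound 1 to compound 3 (beyond the scatter). The values of compound 2 and compound 3 lie within the usual scatter of each other, so no order between them can be read.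

Compound 4 `CN(C)CCC(NC(=O)/C=C/c1ccccc1)c1ccc(Cl)cc1` has not yet been measured. For the measured compounds named here, it differs from compound 3 by chloro in place of methyl on an aromatic carbon, which is the same change, at the same place, as the one that turns compound 1 into compound 2. The earlier instance of this change was a modest rise, but it started from a lower value; compound 3 already stands close to the top of the scale, so a rise of the same size is not expected. The step from compound 3 to compound 4 is estimated to be small, about a number 2 percentage points higher from compound 3 to compound 4 (within the scatter), and this estimate rests on compound 2, which with the same chloro group gives 99%. Compound 4 is therefore expected to give about 99%, most likely between 88% and 108%.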

Compound 4, largest response reached (reported as efficacy), in percent of the reference or control that the assay uses: 128%
For compound 4 the middle estimate is 29 percentage points below the measured one, and the stated range ends below it.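

The swap of chloro for methyl carried over to the second core: it gave a number 31 percentage points higher from compound 3 to compound 4 (beyond the scatter), and this step does not differ from the earlier one, so the rise seen on the core of compound 1 also held on a core without methoxy: the same change on two cores in this assay, a number 20 percentage points higher (beyond the scatter) from compound 1 to compound 2 and a number 31 percentage points higher (beyond the scatter) from compound 3 to compound 4, 11 percentage points apart, within the scatter of two such steps. Hydrogen in place of methoxy behaved the same way, giving a number 29 percentage points higher from compound 2 to compound 4 (beyond the scatter), again in line with its earlier instance: the same change on two cores in this assay, a number 18 percentage points higher (beyond the scatter) from compound 1 to compound 3 and a number 29 percentage points higher (beyond the scatter) from compound 2 to compound 4, 11 percentage points apart, within the scatter of two such steps. Together the four compounds show the two changes adding up in this assay, and compound 4 at 128% shows that the earlier top values were no ceiling, but two instances of each change on one backbone do not show that the swap would carry to other cores, nor do they say why it raises the response.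

The compounds shown leave open whether other groups at the same place, such as fluoro, bromo or trifluoromethyl, would follow chloro, and whether the rise survives if the dimethylamino group gives way to a pyrrolidine or a primary amine. Going by these compounds, they also report only the largest response, so how low a concentration is needed to reach it remains unknown.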